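Replacing 4-fluorobenzyl with isobutyl: a cytotoxicity limit

A few compounds are considered here, and "the series" means these few. Any claim that something is new, unique, unknown or untested is made for them only; others in the source may bear on it.

Measured in an ADME assay on MT4 cells (Homo sapiens) for cytotoxicity; a higher number here means that more compound is tolerated, a lower number that less compound is tolerated:
- compound 1 `COC(=O)N[C@H](C(=O)NN(CCC[C@@](O)(Cc1ccccc1)C(=O)N[C@H]1c2ccccc2C[C@H]1O)Cc1ccc(F)cc1)C(C)(C)C`: > 10000 nM
- compound 2 `COC(=O)N[C@H](C(=O)NN(CCC[C@](O)(Cc1ccccc1)C(=O)N[C@H]1c2ccccc2C[C@H]1O)Cc1ccc(Br)cc1)C(C)(C)C`: > 10000 nM
- compound 3 `COC(=O)N[C@H](C(=O)NN(CCC[C@@](O)(Cc1ccccc1)C(=O)N[C@H]1c2ccccc2C[C@H]1O)Cc1ccc(N(C)C)cc1)C(C)(C)C`: > 10000 nM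

Compound 1 gives > 10000 nM, which is a limit of the assay and not a number. It has company there, as the series shows (the limit of > 10000 nM in this assay, at which 3 of the 3 values shown sit). Among the measured compounds shown here, no measured compound therefore gives a number from which to rank the others.

The next compound is compound 4 `COC(=O)N[C@H](C(=O)NN(CCC[C@@](O)(Cc1ccccc1)C(=O)N[C@H]1c2ccccc2C[C@H]1O)CC(C)C)C(C)(C)C`, still unmeasured. Its difference from compound 1 is isopropyl in place of 4-fluorophenyl on a saturated chain carbon bound to an amine nitrogen, so isopropyl stands in place of 4-fluorophenyl, while the rest of the structure stays the same.

For the measured compounds named here, the one measured step, a step that the two limits leave unreadable from compound 1 to compound 3, concerns a different change and offers no size to carry over. Going by the values given here, with compound 1 at > 10000 nM, the only guide is that limit. No change beyond the scatter is therefore expected in this assay, and the estimate reads a number no higher from compound 1 to compound 4 (the limit leaves the size open). Compound 4 is expected near 10000 nM, with an estimated range of 6000 nM to 20000 nM, and will most likely be reported as a limit again.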

Compound 4, half-maximal cytotoxic concentration: > 10000 nM
Compound 4: a limit, no number; the forecaster's own chance of this, stated with the estimate: 85%; the middle value sits exactly at the limit.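

In this assay compound 4 gives > 10000 nM, a limit and not a number. Its steps from compound 1 and from compound 3 therefore cannot be read. The compounds shown leave open whether 4-fluorobenzyl to isobutyl changes tolerated concentration at all, since all share one limit: the limit of > 10000 nM in this assay, at which 4 of the 4 values shown sit.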